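Two clearance limits and a larger amine side chain

The source may report more compounds than this note shows. Statements on the series, on what has been measured and on what is new or still open speak of the compounds shown alone.

In an ADME assay on microsomes from liver (Homo sapiens) for metabolic stability, read by LC-MS, tested at 1 uM (on this read-out lower numbers stand for slow clearance and higher numbers for fast clearance), compound 1 `NCCCCCOc1ccc([C@H]2CC[C@]3(CC2)OOC2(O3)C3CC4CC(C3)CC2C4)cc1` gives < 7 mL.min-1.g-1 as a limit of the assay and not a number. Compound 2 `NCCOCCOc1ccc([C@H]2CC[C@]3(CC2)OOC2(O3)C3CC4CC(C3)CC2C4)cc1` gives < 7 mL.min-1.g-1 as a limit too. Within the data shown here, compound 2 therefore stands only at a limit, and the one other value shown is also a limit, so the pair sits at the limit of < 7 mL.min-1.g-1 in this assay, at which 2 of the 2 values shown sit, and cannot be ranked. Among the measured compounds shown here, the one measured comparison is a step that the two limits leave unreadable from compound 1 to compound 2 and it offers no size to carry forward. Compound 3 `c1cc([C@H]2CC[C@]3(CC2)OOC2(O3)C3CC4CC(C3)CC2C4)ccc1OCCCNC1CCOCC1` departs from compound 2 through ((oxan-4-yl)amino)methyl in place of 2-aminoethoxy on a saturated chain carbon, two bonds along the chain from an oxygen on an aromatic ring with ((oxan-4-yl)amino)methyl in place of 2-aminoethoxy on a saturated chain carbon, two bonds along the chain from an oxygen on an aromatic ring. For the measured compounds named here, no measured step covers a change of this kind. The expectation therefore leans on the limit of compound 2 at < 7 mL.min-1.g-1 alone and stays cautious. In this assay a small rise or none beyond the scatter is expected, estimated as an at least 1.1-fold higher number from compound 2 to compound 3 (0.05 log units; that floor lies within the scatter) for now. For compound 3 the estimated intrinsic clearance is 8 mL.min-1.g-1 with an expected range from 4 mL.min-1.g-1 to 20 mL.min-1.g-1 on repeated measurement.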

Compound 3, intrinsic clearance in microsomes: 10 mL.min-1.g-1
The estimate for compound 3 lay 1.3-fold (0.10 log units) below the measured number; the range from low to high includes it.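

In this assay, compound 3 is the only one of the three compounds shown that gives a number rather than a limit, at 10 mL.min-1.g-1. This makes two steps partly readable, an at least 1.4-fold higher number from compound 2 to compound 3 (0.15 log units; that floor lies within the scatter) and an at least 1.4-fold higher number from compound 1 to compound 3 (0.15 log units; that floor lies within the scatter), so on a saturated chain carbon, two bonds along the chain from an oxygen on an aromatic ring, the change to ((oxan-4-yl)amino)methyl, with its six-membered non-aromatic ring, is not shown to raise clearance beyond the scatter. The step between compound 1 and compound 2 still cannot be read, and both compounds remain unranked at a limit of the assay: the limit of < 7 mL.min-1.g-1 in this assay, at which 2 of the 3 values shown sit.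

From the compounds shown here alone, the true size of the rise to compound 3 stays open, as only a floor can be read from limits, and that floor does not separate the ring-bearing chain from the open chains of compound 1 and compound 2. Also open, going by these compounds, is whether a cyclohexyl ring, a piperidine or a morpholine in place of the oxan-4-yl ring would give a number close to that of compound 3 in this assay.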